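The source may report more compounds than this note shows. Statements on the series, on what has been measured and on what is new or still open speak of the compounds shown alone.

Compound 1, with the structure `CCNc1nc(Cl)nc(N[C@H](C)c2ccccc2)n1`, is the anchor of this series. Going by the values given here, in an ADME assay on the whole organism for inhibition, with Echinochloa crus-galli var. formosensis as the target, with a stated time of 4 days (a higher number here means a weaker inhibitor, a lower number a stronger inhibitor), compound 1 gives 2690 nM, the lowest of the two numbers measured so far. Among the compounds with values here, its only neighbour is compound 2, drawn as `CCNc1nc(Cl)nc(NC(C)c2ccccc2)n1`, which in this assay gives 9770 nM; the step is a 3.6-fold higher number from compound 1 to compound 2 (0.56 log units; beyond the scatter), and the two compounds differ only in that one is drawn with a defined configuration at the saturated chain carbon and the other without, as noted in the fact that one of compounds 1 and 2 is drawn with a defined configuration and the other without, at the place where they differ.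

The unmeasured compound 3, with the structure `CCCN(C)c1nc(Cl)nc(N[C@H](C)c2ccccc2)n1`, departs from compound 1 at a different place altogether: methyl(propyl)amino in place of ethylamino on an aromatic carbon. Within the data shown here, no measured step covers an exchange of this kind; the single step recorded, from compound 1 to compound 2, concerns only how the stereocentre is drawn and says nothing about replacing the ethylamino group. The expectation for compound 3 therefore rests on compound 1 alone, with a wide band around it to allow for a change in either direction. In this assay compound 3 is estimated at 5000 nM, within 1500 nM to 20000 nM, which means an expected step of a 1.9-fold higher number from compound 1 to compound 3 (0.27 log units; within the scatter).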

Compound 3, half-maximal inhibitory concentration: 9770 nM
Compound 3: middle estimate off by 2.0-fold (0.29 log units), on the low side; measured number inside the range.
By their numbers in this assay, from the lowest: compound 1; then compounds 2 and 3 (each within the scatter of the next).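

Compound 2 left the ethylamino group untouched, so the exchange for methyl(propyl)amino is the only change shown at this aromatic carbon, between two ring nitrogen atoms. In this assay it gives a 3.6-fold higher number from compound 1 to compound 3 (0.56 log units; beyond the scatter), which shows that inhibition of the whole organism responds to what this position carries, and that this exchange weakens it. The exchange alters two counted features together, since the entering group has more heavy atoms and no hydrogen-bond donor where ethylamino has one, and the known difference in how the stereocentre is drawn bears on neither, so nothing available explains the step.

Going by these compounds alone, the single step cannot tell whether the loss follows from the added methyl on the nitrogen, from the longer chain, or from both, and a propylamino group or an ethyl(methyl)amino group in the same place would separate these. It also leaves open whether a smaller group such as methylamino, or an unsubstituted amino group, would hold the value of compound 1 or move it in either direction.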